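Adding a Hydroxy Group to Compound 2

The compounds below may be only part of what the source reports. "The series", "measured", "known", "first", "only" and "open" are said of these compounds alone.

Compound 1 `CC1=CC[C@H](C(C)(C)N=C=S)CC1`: > 100000 nM
Compound 2 `CC1=CC[C@H](C(C)(C)NC(=S)N/N=C/c2ccccc2)CC1`: 22200 nM

Of the compounds shown here, two have been measured. In a functional assay on HT-29 cells (Homo sapiens) for inhibition, read by sulforhodamine B assay, with a stated time of 48 h (on this read-out higher numbers stand for weaker inhibition of growth and lower numbers for stronger inhibition of growth), compound 1 gives > 100000 nM, which is a limit of the assay and not a number, as noted in the limit of > 100000 nM in this assay, at which 1 of the 2 values shown sits. Compound 2 extends compound 1 by a larger tail on the thiourea-type sulfur-bearing group, and in this assay compound 2 gives 22200 nM. Compound 2 therefore stands at the only number actually shown; the one further value is a limit, so no measured step between the two compounds can be stated, and only what the two values show can be said.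

Compound 3 `CC1=CC[C@H](C(C)(C)NC(=S)N/N=C/c2ccc(O)cc2)CC1` is the next compound to be measured. It differs from compound 2 by hydroxy in place of hydrogen on an aromatic carbon. Among the compounds with values here, no step between measured compounds is available to guide the expectation. On that footing, the change from compound 2 to compound 3 is expected to move the read-out by no more than the usual scatter, in no firm direction. Compound 3 is estimated at 16000 nM, within a range from 5000 nM to 50000 nM, which is an expected step of a 1.4-fold lower number from compound 2 to compound 3 (0.14 log units; within the scatter).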

Compound 3, concentration for total growth inhibition: > 100000 nM
Compound 3 was reported as a limit (the forecaster's own chance of this, stated with the estimate: 10%); middle value at least 6.2-fold (0.79 log units) away from the limit.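

In this assay, within the data shown here, the change from phenyl to 4-hydroxyphenyl gives the first step that can be read, and that step is an at least 4.5-fold higher number from compound 2 to compound 3 (0.65 log units; beyond the scatter). In this assay, as far as these compounds go, compound 3 gives > 100000 nM, which is a limit of the assay and not a number, so the true size of the step stays unknown and only its smallest size can be stated. The result shows that growth inhibition is sensitive to this change on an aromatic carbon, para to a large group, where hydroxy in place of hydrogen gives weaker inhibition of growth, and that the measurable range is narrow for this series: the limit of > 100000 nM in this assay, at which 2 of the 3 values shown sit.

From the compounds shown here alone, it remains open whether a methoxy group, an amine or a fluorine atom in the same place would also push the read-out to the limit or would keep it near the level of compound 2. Going by these compounds, it also remains open whether a hydroxy group on another carbon of the aromatic ring would give the same outcome.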